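This account rests on a few compounds, and the source may have more. Where it says the series, first, only, none or still open, it means among the compounds named here.

Measured compounds:
- compound 1, `CCc1ccc(Nc2cc(NC(=O)Nc3c(Cl)cccc3Cl)ncn2)cc1`, 31.5%
- compound 2, `COc1ccc(F)cc1Nc1cc(NC(=O)Nc2c(Cl)cccc2Cl)ncn1`, 38.1%
- compound 3, `Cc1ccc(Nc2cc(NC(=O)Nc3c(Cl)cccc3Cl)ncn2)cc1C`, 47.5%

All three were tested in a functional assay on NCI-H520 cells (Homo sapiens) for inhibition, read by MTT assay, with a stated time of 48 h, tested at 10 uM; a lower number here means less inhibition, a higher number more inhibition at the concentration tested (going by the name of the read-out). Compound 3 stands highest of the three numbers in this assay, but only the gap to compound 1 is beyond the scatter: a number 16 percentage points higher from compound 1 to compound 3 (beyond the scatter). The gap to compound 2, a number 9.4 percentage points higher from compound 2 to compound 3 (within the scatter), is within the scatter, so compound 2 and compound 3 cannot be told apart.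

Compound 4, `Cc1cc(F)cc(Nc2cc(NC(=O)Nc3c(Cl)cccc3Cl)ncn2)c1`, has not been measured. It differs from compound 3 in one place: 3-fluoro-5-methylphenyl in place of 3,4-dimethylphenyl on a nitrogen on an aromatic ring. The measured steps that bear on this are those at the same place: a number 6.6 percentage points higher from compound 1 to compound 2 (within the scatter) and a number 16 percentage points higher from compound 1 to compound 3 (beyond the scatter), both of which swap one substituted phenyl for another. Within the data shown here, only one of these steps exceeded the scatter, and the step of a number 9.4 percentage points higher from compound 2 to compound 3 (within the scatter), which already exchanges a fluorine-bearing phenyl for the dimethylphenyl, stayed within it. A step of similar size, a number 6.5 percentage points lower from compound 3 to compound 4 (within the scatter), is expected here, within the scatter. Compound 4 is therefore estimated at 41%, with a range from 27% to 55%.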

Compound 4, a percentage reported as inhibition, at one concentration (the size of the read-out at that concentration, not a potency): 60.5%
Compound 4: the middle estimate sits 19.5 percentage points below what was measured; the measured number lies above the stated range.
By their numbers in this assay, from the lowest: compounds 1, 2 and 3 (each within the scatter of the next, the first and the last beyond it); then compound 4.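

In this assay the group on the amino nitrogen still moves the number beyond the scatter when its size stays the same: 3-fluoro-5-methylphenyl and 3,4-dimethylphenyl both have 8 heavy atoms and differ by one carbon traded for one fluorine, yet the swap gives a clear rise (a number 13 percentage points higher from compound 3 to compound 4 (beyond the scatter)). Among these compounds, compound 4 is also the only compound here whose steps to all the others lie beyond the scatter (a number 22.4 percentage points higher from compound 2 to compound 4 (beyond the scatter); a number 29 percentage points higher from compound 1 to compound 4 (beyond the scatter)), so it now stands highest on its own. Nothing available here explains this rise.

The compounds shown do not separate the effect of the fluorine from that of the methyl's changed place on the ring. They also leave open how a phenyl ring carrying an amine, a carboxylic acid or a longer chain would fare.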